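From Compound 3 to Compound 4: a Ring Swap

This account rests on a few compounds, and the source may have more. Where it says the series, first, only, none or still open, it means among the compounds named here.

Measured so far:
compound 1, `CC(C)n1ncc2c(C(=O)Nc3ccccc3)cccc21`, 11900 nM
compound 2, `CC(C)n1ncc2c(C(=O)NCc3ccccc3)cccc21`, 15200 nM
compound 3, `CC(C)n1ncc2c(C(=O)NCc3cn(-c4ccc(F)cc4)nn3)cccc21`, > 40000 nM

In a functional assay on PC-3 cells (Homo sapiens) for inhibition, read by MTT assay, with a stated time of 72 h (on this read-out higher numbers stand for weaker inhibition and lower numbers for stronger inhibition), compound 1 gives 11900 nM. Compound 2 carries a benzyl in place of the phenyl on the amide-type nitrogen, and the step is a 1.3-fold higher number from compound 1 to compound 2 (0.11 log units; within the scatter). For compound 3 this assay reports only a limit, > 40000 nM, and no number, so compound 3 stands at the edge of what this assay can resolve (the limit of > 40000 nM in this assay, at which 1 of the 3 values shown sits).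

Compound 4, `Cc1cccc(-n2cc(CNC(=O)c3cccc4c3cnn4C(C)C)nn2)c1`, differs from compound 3 by 3-methylphenyl in place of 4-fluorophenyl on an aromatic nitrogen. For the measured compounds named here, no measured step touches this place; the single measured step, from compound 1 to compound 2, sits elsewhere on the molecule and lies within the scatter, so it offers no guide to direction. With compound 3 at the limit, the expectation for compound 4 is a number again near or beyond that limit, a step that the limit leaves unreadable from compound 3 to compound 4. The estimate for compound 4 is 50000 nM, with a range from 20000 nM to 150000 nM.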

Compound 4, half-maximal inhibitory concentration: 32300 nM
Compound 4: the middle estimate sits 1.5-fold (0.19 log units) above what was measured; low and high end bracket the measured number.
By their numbers in this assay, from the lowest: compounds 1 and 2 (each within the scatter of the next); then compound 4. At a limit, above all of these: compound 3.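

Putting 3-methylphenyl in place of 4-fluorophenyl at this place, on an aromatic nitrogen of the five-membered ring, gives in this assay an at least 1.2-fold lower number from compound 3 to compound 4 (0.09 log units; that floor lies within the scatter). Compound 4 thus gives this part of the molecule a measured number rather than only a limit, but the floor of the step lies within the scatter, so the swap cannot be called a real gain. The true size of the step stays unknown because the value for compound 3 is a limit: the limit of > 40000 nM in this assay, at which 1 of the 4 values shown sits.

The swap removes the fluorine, adds a methyl and moves the substituent on the phenyl ring all at once, so the compounds shown cannot separate these three changes. As far as these compounds go, how a plain phenyl, a 4-methylphenyl or a phenyl bearing an amine or a carboxylic acid would read at this place also remains open.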